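Propyl to butyl on the shared core

This account rests on a few compounds, and the source may have more. Where it says the series, first, only, none or still open, it means among the compounds named here.

Of the compounds shown here, two have numbers so far: compound 1 (`CCCOc1ccc([C@@H]2CC(=O)c3cc(CC=C(C)C)c(OC)cc3O2)cc1`) and compound 2 (`COc1cc2c(cc1CC1OC1(C)C)C(=O)C[C@@H](c1ccc(O)cc1)O2`). In a functional assay on MCF7 cells (Homo sapiens) for inhibition, read by sulforhodamine B assay, with a stated time of 48 h, tested at 50 uM (on this read-out higher numbers stand for more inhibition of growth at the one concentration tested and lower numbers for less inhibition of growth), compound 1 gives 60% and holds the lower of the two numbers, while compound 2 gives 98% and stands higher by a gap beyond the scatter. For the measured compounds named here, these two compounds do not form a step that differs in one place, so the series offers no measured step for the present change.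

Compound 3 (`CCCCOc1ccc([C@@H]2CC(=O)c3cc(CC=C(C)C)c(OC)cc3O2)cc1`) departs from compound 1 in one place: methyl in place of hydrogen on a saturated chain carbon, three bonds along the chain from an oxygen on an aromatic ring with methyl in place of hydrogen on a saturated chain carbon, three bonds along the chain from an oxygen on an aromatic ring. The same difference reads propyl to butyl. With compound 1 at 60% as the only close reference, the expectation stays near that number and favours no direction. In this assay the estimate expects no change at the digits printed from compound 1 to compound 3 (within the scatter) and thus nothing beyond the scatter. The estimated value for compound 3 is 60% with an expected range from 42% to 78% as the working figure.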

Compound 3, percent growth inhibition at one concentration: 57%
Beside the measured number, compound 3's estimate is 3 percentage points above it; the range from low to high includes it.
By their numbers in this assay, from the lowest: compounds 3 and 1 (each within the scatter of the next); then compound 2.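

Working notes on the chain: the first measured step of the series sits at this position, and in this assay the change from propyl to butyl gives a number 3 percentage points lower from compound 1 to compound 3 (within the scatter) on the shared core. Methyl in place of hydrogen on a saturated chain carbon, three bonds along the chain from an oxygen on an aromatic ring, therefore leaves the growth inhibition read-out indistinguishable at the one concentration tested, so this position accepts the added carbon with no resolved effect in either direction. No measurement on hand bears on the reason for this outcome.

On these data alone, a single step between two chain lengths defines no trend, and it remains open whether a shorter ethyl chain or a longer pentyl chain on the same oxygen would stay within the scatter of these two compounds. As far as these compounds go, it is equally open whether an amine or a carboxylic acid at the end of the chain would be tolerated as the added methyl is here, and a single-concentration read-out cannot show whether any difference hides behind the matching numbers.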